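The source may report more compounds than this note shows. Statements on the series, on what has been measured and on what is new or still open speak of the compounds shown alone.

Compounds measured in a functional assay on U-251 cells (Homo sapiens); on this read-out higher numbers stand for weaker inhibition of growth and lower numbers for stronger inhibition of growth:
- compound 1, `Oc1cc(-c2ccc(Cl)cc2)nc2ncccc12`: 39800 nM
- compound 2, `COc1ccccc1-c1cc(O)c2ccc(C)nc2n1`: > 100000 nM (a limit of the assay, not a number)
- compound 3, `COc1ccccc1-c1cc(O)c2cccnc2n1`: 67600 nM

Compound 3 at 67600 nM and compound 1 at 39800 nM lie within the scatter of each other. Going by the values given here, these are the only two true numbers. Compound 2 gives only a limit.

Compound 4, `COc1ccccc1-c1cc(O)c2c(C)ccnc2n1`, is not yet measured in this assay. It differs from compound 3 by one change: methyl in place of hydrogen on an aromatic carbon. This is methyl in place of hydrogen on an aromatic carbon, opposite the ring nitrogen.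

Among the compounds with values here, one measured step bears on this, the loss of a methyl from another carbon of that ring: an at least 1.4-fold lower number from compound 2 to compound 3 (0.17 log units; that floor lies within the scatter). Its size is only a floor because of the limit of > 100000 nM in this assay, at which 1 of the 3 values shown sits. It therefore gives no firm size for a methyl, and at most a weak hint towards a higher number when one is added. The expected change is a 1.2-fold higher number from compound 3 to compound 4 (0.07 log units; within the scatter), which is estimated to stay within the scatter. For compound 4 the estimate is 80000 nM, with an expected range of 40000 nM to 160000 nM. A reading reported only as a limit is also possible.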

Compound 4, concentration for 50% growth inhibition: 35500 nM
Estimate against measurement, compound 4: 2.3-fold (0.35 log units) above, and the stated range ends above it.
By their numbers in this assay, from the lowest: compounds 4, 1 and 3 (each within the scatter of the next). At a limit, above all of these: compound 2.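

In this assay the new step reads a 1.9-fold lower number from compound 3 to compound 4 (0.28 log units; within the scatter). Going by these compounds alone, this is the first methyl step with a true number at both ends, so its size can be read, and at this position, opposite the ring nitrogen, that size does not separate methyl from hydrogen. The earlier methyl step, on another carbon of that ring, gave only a floor because of the assay limit: the limit of > 100000 nM in this assay, at which 1 of the 4 values shown sits.

On these data alone, whether an ethyl, a methoxy or an amine at this position would move the number beyond the scatter remains open. Compound 2 gives only a limit, so the size of a methyl on that other carbon cannot be read and cannot be set against the step at this position.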